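Methyl on the benzothiazole of a pyrazole-carboxamide series

The source may hold more compounds than are shown below. What is called first, only, known or untested is meant among the compounds shown, and "the series" means these compounds.

Measured so far:
compound 1, `O=C(Nc1nc2ccccc2s1)c1cn(-c2ccccc2)nc1-c1ccccc1` — 13500 nM
compound 2, `O=C(Nc1nc2ccccc2s1)c1cn(-c2ccccc2)nc1-c1ccc(F)cc1` — 9010 nM

In a functional assay on A549 cells (Homo sapiens) for cytotoxicity, read by MTT assay, with a stated time of 72 h (on this read-out lower numbers stand for stronger inhibition and higher numbers for weaker inhibition), compound 1 gives 13500 nM and compound 2 gives 9010 nM. Within the data shown here, the one change between them, a 1.5-fold lower number from compound 1 to compound 2 (0.18 log units; within the scatter), does not separate the two. Compound 2 thus holds the lower of the two numbers, but the gap to compound 1 is within the scatter, so no order between them can be claimed.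

Compound 3, `Cc1ccc2nc(NC(=O)c3cn(-c4ccccc4)nc3-c3ccc(F)cc3)sc2c1`, differs from compound 2 by methyl in place of hydrogen on an aromatic carbon, read one bond further out as 1,3-benzothiazol-2-yl to 6-methyl-1,3-benzothiazol-2-yl. Among the measured compounds shown here, no measured step touches this part of the shared core; the only step known, from compound 1 to compound 2, sits on a different ring and was itself within the scatter. There is therefore no basis for expecting a step beyond the scatter in this assay in either direction.

Compound 3 is estimated at 8000 nM, with a range of 3000 nM to 22000 nM, meaning an expected step of a 1.1-fold lower number from compound 2 to compound 3 (0.05 log units; within the scatter) that stays within the scatter.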

Compound 3, half-maximal inhibitory concentration: 24600 nM
Compound 3: the middle estimate sits 3.1-fold (0.49 log units) below what was measured; the measured number lies above the stated range.
By their numbers in this assay, from the lowest: compounds 2, 1 and 3 (each within the scatter of the next, the first and the last beyond it).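

In this assay, among these compounds, the change from 1,3-benzothiazol-2-yl to 6-methyl-1,3-benzothiazol-2-yl gives the first step that lies beyond the scatter, a 2.7-fold higher number from compound 2 to compound 3 (0.44 log units; beyond the scatter). The number at this position therefore responds to methyl in place of hydrogen, modestly and towards weaker inhibition, whereas fluoro in place of hydrogen on a different ring gave only a 1.5-fold lower number from compound 1 to compound 2 (0.18 log units; within the scatter), which is within the scatter. No measurement shown here bears on the reason for this step.

Methyl is the only group shown at this position, so it remains open whether a chlorine, a methoxy group or an amine there would move the number the same way. Also open, going by these compounds, is whether methyl would give a similar step on the core of compound 1, which lacks the fluoro group.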